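Methyl on the hydroxy oxygen of compound 1

The compounds below may be only part of what the source reports. "The series", "measured", "known", "first", "only" and "open" are said of these compounds alone.

In a functional assay on NCI-H522 cells (Homo sapiens) for inhibition, read by sulforhodamine B assay, with a stated time of 48 h (on this read-out lower numbers stand for stronger inhibition of growth and higher numbers for weaker inhibition of growth), compound 1 (`O=C(Nc1cccc(-n2cc(-c3ccncc3)c(-c3ccc(Cl)c(O)c3)n2)c1)Nc1cccc(C(F)(F)F)c1`) gives 1460 nM and compound 2 (`COc1cc(-c2nn(-c3cccc(NC(=O)c4cccc(C(F)(F)F)c4)c3)cc2-c2ccncc2)ccc1Cl`) gives 1050 nM. Going by the values given here, these two values lie within the scatter of each other, so compound 1 stands level with the only other number available.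

Compound 3 (`COc1cc(-c2nn(-c3cccc(NC(=O)Nc4cccc(C(F)(F)F)c4)c3)cc2-c2ccncc2)ccc1Cl`) carries methyl in place of hydrogen on an oxygen on an aromatic ring of compound 1, turning hydroxy to methoxy and 4-chloro-3-hydroxyphenyl to 4-chloro-3-methoxyphenyl: methyl in place of hydrogen on an oxygen on an aromatic ring.

Among the compounds with values here, no measured pair differs in one place, so the data give no step size for this change. No shift beyond the scatter, in either direction, is expected in this assay. The estimated step is a 1.1-fold lower number from compound 1 to compound 3 (0.05 log units; within the scatter), which is expected to stay within the scatter. For compound 3 the estimate is 1300 nM, with an expected range from 550 nM to 3000 nM.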

Compound 3, concentration for 50% growth inhibition: 714 nM
Beside the measured number, compound 3's estimate is 1.8-fold (0.26 log units) above it; the measured number falls inside the stated range.
By their numbers in this assay, from the lowest: compounds 3, 2 and 1 (each within the scatter of the next, the first and the last beyond it).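

In this assay, methyl in place of hydrogen on the oxygen of the 4-chloro-3-hydroxyphenyl group gives a 2.0-fold lower number from compound 1 to compound 3 (0.31 log units; beyond the scatter): a modest step, but the first at this position, and it shows that the hydrogen on this oxygen is not needed to keep growth inhibition at this level. With the 4-chloro-3-methoxyphenyl group held constant, (3-(trifluoromethyl)phenyl)amino in place of 3-(trifluoromethyl)phenyl on a carbonyl carbon gives a 1.5-fold lower number from compound 2 to compound 3 (0.17 log units; within the scatter), so this change does not separate the two compounds in this read-out. No supporting data bear on why the methyl step takes this size.

Open, from the compounds shown here alone, is whether an ethyl group or a longer chain on this oxygen, or an amine in place of the hydroxy, would extend the step. Also open, going by these compounds, is whether the methyl step holds with the carbonyl substituent of compound 2.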